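Trading the Nitrophenoxy Group for a Benzyl Group

The compounds below may be only part of what the source reports. "The series", "measured", "known", "first", "only" and "open" are said of these compounds alone.

Three compounds share one core and differ only in the group on an oxygen on a saturated carbon. Compound 1 `Cc1ccc(C#N)c(OC(C)(C)C2OCC(C/C=C\CCC(=O)O)C(c3cccnc3)O2)c1` gives 50 nM in an assay for inhibition of Thromboxane-A synthase (Homo sapiens), using microsomes; a lower number here means a stronger inhibitor, a higher number a weaker inhibitor. Compound 2 `CC(C)(Oc1ccccc1Br)C1OCC(C/C=C\CCC(=O)O)C(c2cccnc2)O1` gives 29 nM in this assay, and a 1.7-fold lower number from compound 1 to compound 2 (0.24 log units; within the scatter). For compound 3 `CC(C)(Oc1ccccc1[N+](=O)[O-])C1OCC(C/C=C\CCC(=O)O)C(c2cccnc2)O1` only a limit of < 10 nM is reported in this assay, so compound 3 stands at the strong end of the numbers shown, as noted in the limit of < 10 nM in this assay, at which 1 of the 3 values shown sits. The steps of an at least 5.0-fold lower number from compound 1 to compound 3 (0.69 log units; beyond the scatter) and an at least 2.9-fold lower number from compound 2 to compound 3 (0.46 log units; beyond the scatter) both run toward compound 3.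

Compound 4 `CC(C)(Cc1ccccc1)C1OCC(C/C=C\CCC(=O)O)C(c2cccnc2)O1` brings a different change: benzyl in place of 2-nitrophenoxy on a saturated chain carbon bound to two saturated chain carbons and a saturated ring carbon. Going by the values given here, no measured step removes the oxygen link, so the measured steps bear on it only loosely; they show that the 2-nitrophenoxy group of compound 3 gave the lowest number, and compound 4 gives that group up entirely. A move back toward the numbers of compound 1 and compound 2, or beyond them, is therefore expected, so an at least 7.0-fold higher number from compound 3 to compound 4 (0.84 log units; beyond the scatter) is estimated. Compound 4 is expected to give about 70 nM in this assay, plausibly between 15 nM and 300 nM.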

Compound 4, half-maximal inhibitory concentration: 12 nM
Compound 4: middle estimate off by 5.8-fold (0.77 log units), on the high side; the whole stated range lies above it.
By their numbers in this assay, from the lowest: compound 4; then compounds 2 and 1 (each within the scatter of the next). At a limit, below all of these: compound 3.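

In this assay benzyl, on a saturated chain carbon bound to two saturated chain carbons and a saturated ring carbon, brings a 2.4-fold lower number from compound 2 to compound 4 (0.38 log units; beyond the scatter) and a 4.2-fold lower number from compound 1 to compound 4 (0.62 log units; beyond the scatter) when it replaces the oxygen-linked groups, so neither the oxygen link nor a substituent on the ring is required for a low number at this position. Compound 3 stands only at a limit of the assay: the limit of < 10 nM in this assay, at which 1 of the 4 values shown sits. The step of an at least 1.2-fold higher number from compound 3 to compound 4 (0.07 log units; that floor lies within the scatter) has a floor inside the scatter, so 2-nitrophenoxy and benzyl cannot be ranked against each other.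

The compounds shown leave open how a benzyl carrying a nitro group or a bromine on its ring would compare with compound 4. They also leave open whether an aromatic ring is needed here at all, a question that a cyclohexylmethyl group or a plain methyl group could address.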